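Working notes on two limits and a rearranged analogue

The source may hold more compounds than are shown below. What is called first, only, known or untested is meant among the compounds shown, and "the series" means these compounds.

Compound 1 `CN/C(C)=N/c1cc(-c2ccccc2)nn1-c1ccccc1`: in a functional assay on NPC-TW01 cells (Homo sapiens) for inhibition, read by MTT assay, with a stated time of 72 h (a higher number here means a weaker inhibitor of growth, a lower number a stronger inhibitor of growth), compound 1 gives > 50000 nM, which is a limit of the assay.
Compound 2 `CC/C(=N\c1cc(-c2ccccc2)nn1-c1ccccc1)NC`: in this assay compound 2 gives > 50000 nM, again a limit of the assay.

Compound 2 therefore stands only at a limit; no number is known for it, and the same holds for the other measured compound, as both sit at the limit of > 50000 nM in this assay, at which 2 of the 2 values shown sit. Within the data shown here, the single measured step, a step that the two limits leave unreadable from compound 1 to compound 2, cannot be read in size or direction, since both of its ends are limits.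

Compound 3 `C/C(=N\c1cc(-c2ccccc2)nn1-c1ccccc1)N(C)C` differs from compound 2 by a group of 6 heavy atoms (4 carbon, 2 nitrogen; no ring) in place of a group of 6 heavy atoms (4 carbon, 2 nitrogen; no ring), on an aromatic carbon. Among the measured compounds shown here, no measured step bears readably on this change. With both measured compounds at the limit (the limit of > 50000 nM in this assay, at which 2 of the 2 values shown sit), the step that the limit leaves unreadable from compound 2 to compound 3 is expected to be small or not readable, and compound 3 is most likely to be reported as a limit as well. Compound 3 is accordingly estimated at 80000 nM in this assay, with a range from 20000 nM to 300000 nM.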

Compound 3, concentration for 50% growth inhibition: > 50000 nM
Compound 3 gave a limit, no number; the forecaster's own chance of this, stated with the estimate: 85%; the middle value lies beyond the limit too.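

Among these compounds, compound 3 joins compound 1 and compound 2 at a limit in this assay, and no step among the three can be read: the limit of > 50000 nM in this assay, at which 3 of the 3 values shown sit.
The compounds shown leave open whether any change on the shared core gives a readable number in this assay at all.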